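A few compounds are considered here, and "the series" means these few. Any claim that something is new, unique, unknown or untested is made for them only; others in the source may bear on it.

Three compounds share one core and differ only in the group on one aromatic carbon. In an assay on CHO-K1 cells for displacement of a labelled ligand from melanin-concentrating hormone receptor 1 (Homo sapiens), read by scintillation proximity assay, with a stated time of 2 h (a higher number here means a weaker inhibitor, a lower number a stronger inhibitor), compound 1 `Cc1nc(N(C)C2CCCC2)nc2ccc(NC(=O)/C=C/c3ccc(Cl)cc3)cc12` gives 399 nM. Compound 2 `COCCC1(O)CCN(c2nc(C)c3cc(NC(=O)/C=C/c4ccc(Cl)cc4)ccc3n2)CC1` gives 245 nM in this assay, and compound 3 `CCCC1(O)CCN(c2nc(C)c3cc(NC(=O)/C=C/c4ccc(Cl)cc4)ccc3n2)CC1` gives 245 nM. Measured against the others, compound 3 sits at the low end together with its nearest neighbour: a 1.6-fold lower number from compound 1 to compound 3 (0.21 log units; within the scatter), a 1.6-fold lower number from compound 1 to compound 2 (0.21 log units; within the scatter), and no change at the digits printed from compound 2 to compound 3 (within the scatter). Compound 4 `Cc1nc(N2CCC(O)(C3CCC3)CC2)nc2ccc(NC(=O)/C=C/c3ccc(Cl)cc3)cc12` carries cyclobutyl in place of propyl on a saturated ring carbon. The step that bears most directly on this is the earlier swap on the same saturated ring carbon, no change at the digits printed from compound 2 to compound 3 (within the scatter), and the two larger exchanges also stayed within the scatter. No step beyond the scatter is therefore expected, a 1.0-fold higher number from compound 3 to compound 4 (0.01 log units; within the scatter). Compound 4 is estimated at 250 nM, within 110 nM to 560 nM.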

Compound 4, half-maximal inhibitory concentration: 206 nM
The estimate for compound 4 lay 1.2-fold (0.08 log units) above the measured number, and the stated range covers the measured number.
By their numbers in this assay, from the lowest: compounds 4, 2, 3 and 1 (each within the scatter of the next).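

In this assay, a ring on this saturated ring carbon reads the same as the open chains: cyclobutyl gives a 1.2-fold lower number from compound 3 to compound 4 (0.08 log units; within the scatter) and a 1.2-fold lower number from compound 2 to compound 4 (0.08 log units; within the scatter) against the chains. Exchanging the whole group gives a 1.9-fold lower number from compound 1 to compound 4 (0.29 log units; within the scatter) so none of the groups shown here separates from the others beyond the scatter. No measurement here explains this sameness.

Still open, from the compounds shown here alone, is whether an amine, a carboxylic acid or a much longer chain on this carbon would move the number beyond the scatter.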